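Urea Bridge Replaces Amide: What Compound 3 Might Show

A few compounds are considered here, and "the series" means these few. Any claim that something is new, unique, unknown or untested is made for them only; others in the source may bear on it.

Of the compounds shown here, two from this set have been tested in a functional assay on OVCAR-4 cells (Homo sapiens) for inhibition, read by sulforhodamine B assay, with a stated time of 48 h; on this read-out lower numbers stand for stronger inhibition of growth and higher numbers for weaker inhibition of growth. Compound 1, `O=C(Nc1cccc(-n2cc(-c3ccncc3)c(-c3ccc(Cl)c(O)c3)n2)c1)Nc1ccc(Cl)c(Cl)c1`, carries a urea bridge to a dichlorophenyl group; in this assay compound 1 gives > 32500 nM, which is a limit of the measurement and not a number. Compound 2, `COc1cc(-c2nn(-c3cccc(NC(=O)c4cccc(C(F)(F)F)c4)c3)cc2-c2ccncc2)ccc1Cl`, joins a related core to a benzamide bearing a trifluoromethyl group; in this assay compound 2 gives > 50000 nM, again a limit rather than a number. For the measured compounds named here, compound 2 thus stands at a limit only, and the one further value shown is a limit as well, so no measured step between compounds exists and no change can be sized from them. Compound 3, `COc1cc(-c2nn(-c3cccc(NC(=O)Nc4ccc(Cl)c(C(F)(F)F)c4)c3)cc2-c2ccncc2)ccc1Cl`, differs from compound 2 by (4-chloro-3-(trifluoromethyl)phenyl)amino in place of 3-(trifluoromethyl)phenyl on a carbonyl carbon. Going by the values given here, with the limit of > 32500 nM in this assay, at which 1 of the 2 values shown sits, and the limit of > 50000 nM in this assay, at which 1 of the 2 values shown sits, as the only evidence, the step of a number no higher from compound 2 to compound 3 (the limit leaves the size open) is expected to stay within the scatter, in no particular direction. Compound 3 is expected to give about 50000 nM, in a range from 20000 nM to 100000 nM, and quite possibly to be reported again only as a limit.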

Compound 3, concentration for total growth inhibition: 25600 nM
Estimate against measurement, compound 3: 2.0-fold (0.29 log units) above; the range from low to high includes it.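

In this assay, for the compounds shown here, compound 3 provides the first reading in this set that is a number and not a limit, so this position on the carbonyl carbon can now be tied to a value at the level of a single change. Placing (4-chloro-3-(trifluoromethyl)phenyl)amino in place of 3-(trifluoromethyl)phenyl on a carbonyl carbon gives an at least 1.9-fold lower number from compound 2 to compound 3 (0.29 log units; that floor lies within the scatter), which fixes a floor for the change but not its full size, and that floor alone does not take the change beyond the usual scatter. The step has only a floor because the reading for compound 2 is a limit and not a number: the limit of > 50000 nM in this assay, at which 1 of the 3 values shown sits.

The entering group brings in a nitrogen and a chlorine together, so the compounds shown cannot separate what each of the two contributes to the step, and a compound carrying only one of them would be needed to do so. They also leave open how a carboxylic acid or a dimethylamino group at this place on the carbonyl carbon would read in this assay.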